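A few compounds are considered here, and "the series" means these few. Any claim that something is new, unique, unknown or untested is made for them only; others in the source may bear on it.

Measured compounds: compound 1 `C[C@@H](C(=O)NC1CCCCC1)[C@H]1CC[C@@H](c2ccnc3ccc(F)cc32)CC1`, which in an assay on blood for inhibition of Indoleamine 2,3-dioxygenase 1 (Homo sapiens), read by mass spectrometry, with stated times of 4 h and 18 h (a higher number here means a weaker inhibitor, a lower number a stronger inhibitor), gives for compound 1 470 nM; and compound 2 `C[C@@H](NCc1ccc(Cl)cc1)[C@H]1CC[C@@H](c2ccnc3ccc(F)cc32)CC1`. In this assay compound 2 gives > 1000 nM, which is a limit of the assay and not a number.

Compound 2 thus stands at the limit of > 1000 nM in this assay, at which 1 of the 2 values shown sits, the weaker end of what is shown. For the measured compounds named here, the one measured step, an at least 2.1-fold higher number from compound 1 to compound 2 (0.32 log units; beyond the scatter), exchanged a cyclohexylcarbamoyl for a (4-chlorobenzyl)amino and lost potency. Compound 3 `C[C@@H](NC(=O)c1cccc(Cl)c1)[C@H]1CC[C@@H](c2ccnc3ccc(F)cc32)CC1` differs from compound 2 by (3-chlorophenyl)carbonyl in place of 4-chlorobenzyl on an amine nitrogen, so a carbonyl returns to the nitrogen, as in compound 1. Because an at least 2.1-fold higher number from compound 1 to compound 2 (0.32 log units; beyond the scatter) weakened the inhibitor when the carbonyl left, compound 3 is expected to move the other way, a step of an at least 1.6-fold lower number from compound 2 to compound 3 (0.22 log units; that floor lies within the scatter) toward stronger inhibition in this assay. Compound 3 is therefore estimated at 600 nM, within 200 nM to 2000 nM.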

Compound 3, half-maximal inhibitory concentration: 97 nM
Compound 3: the middle estimate sits 6.2-fold (0.79 log units) above what was measured, and the stated range ends above it.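

Placing (3-chlorophenyl)carbonyl in place of 4-chlorobenzyl on the amine nitrogen gives an at least 10-fold lower number from compound 2 to compound 3 (1.01 log units; beyond the scatter) in this assay, a large step toward stronger inhibition. This shows that the group on this nitrogen can strongly change the read-out, and that a carbonyl-bearing group here can restore inhibition that a benzyl group does not show. The true size of the step remains unknown, since compound 2 has a limit and not a number: the limit of > 1000 nM in this assay, at which 1 of the 3 values shown sits.

The exchange alters both the carbonyl and the printed place of the chlorine, so the compounds shown do not separate the two. On these data alone, whether (4-chlorophenyl)carbonyl, an unsubstituted benzoyl or a sulfonyl on this nitrogen would hold the same gain stays open.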